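This account rests on a few compounds, and the source may have more. Where it says the series, first, only, none or still open, it means among the compounds named here.

Measured so far:
Compound 1 `Cc1ccc2occ(C3N=C(c4ccccc4)SS3)c(=O)c2c1`: in a functional assay on COLO 205 cells (Homo sapiens) for inhibition, read by sulforhodamine B assay, with a stated time of 48 h (a lower number here means a stronger inhibitor, a higher number a weaker inhibitor), compound 1 gives > 100000 nM, a limit of the assay rather than a number.
Compound 2 `O=c1c(C(=S)Nc2ccccc2)coc2cc(Cl)ccc12`: in this assay compound 2 gives > 100000 nM, likewise a limit and not a number.

Compound 1 thus stands at the limit of > 100000 nM in this assay, at which 2 of the 2 values shown sit. Within the data shown here, no step between measured compounds is available. Compound 3 `O=c1c(C2N=C(c3ccccc3)SS2)coc2ccccc12` differs from compound 1 by hydrogen in place of methyl on an aromatic carbon. With both measured values at the limit, no step beyond the scatter in this assay is expected in either direction. For compound 3 the expected result is 150000 nM, range 30000 nM to 1000000 nM, most likely again reported only as a limit. The expected step is a step that the limit leaves unreadable from compound 1 to compound 3, within the scatter.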

Compound 3, half-maximal inhibitory concentration: > 100000 nM
Compound 3 gave a limit, no number; the forecaster's own chance of this, stated with the estimate: 85%; the middle value is on the limit's open side.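

In this assay no step can be read from compound 1 to compound 3, as both results are limits and not numbers: the limit of > 100000 nM in this assay, at which 3 of the 3 values shown sit.

The compounds shown leave open what effect hydrogen in place of methyl has, and whether any close relative gives a readable number.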